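Methoxymethyl Benzyl Amide in Place of the Pyridylmethyl Group

A few compounds are considered here, and "the series" means these few. Any claim that something is new, unique, unknown or untested is made for them only; others in the source may bear on it.

Compound 1 `Cc1cccc(CNC(=O)c2nn(-c3ccc(F)cc3)c(OC[C@@H](O)C[C@@H](O)CC(=O)O)c2C(C)C)c1`: 4.9 nM
Compound 2 `CC(C)c1c(C(=O)NCc2ccccn2)nn(-c2ccc(F)cc2)c1OC[C@@H](O)C[C@@H](O)CC(=O)O`: 25 nM

Both compounds were tested in an assay on microsomes from liver for inhibition of 3-hydroxy-3-methylglutaryl-coenzyme A reductase (Rattus norvegicus); on this read-out higher numbers stand for weaker inhibition and lower numbers for stronger inhibition. Compound 2 holds the highest of the two numbers in this assay; its nearest neighbour is compound 1, and the step of a 5.1-fold higher number from compound 1 to compound 2 (0.71 log units; beyond the scatter) lies beyond the scatter, so compound 2 is the weaker inhibitor of the pair.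

Compound 3 `COCc1cccc(CNC(=O)c2nn(-c3ccc(F)cc3)c(OC[C@@H](O)C[C@@H](O)CC(=O)O)c2C(C)C)c1` has not yet been measured. It differs from compound 2 by 3-(methoxymethyl)phenyl in place of pyridin-2-yl on a saturated chain carbon bound to an amide-type nitrogen. Within the data shown here, the one measured step that bears on this change is a 5.1-fold higher number from compound 1 to compound 2 (0.71 log units; beyond the scatter), which exchanged a 3-methylphenyl for pyridin-2-yl at the same place and raised the number by a modest but real amount. Compound 3 runs in the opposite direction: the pyridin-2-yl gives way to a carbon-only ring carrying a methoxymethyl group, a close relative of the 3-methylphenyl of compound 1. A return toward the number of compound 1 is therefore expected, as a 4.2-fold lower number from compound 2 to compound 3 (0.62 log units; beyond the scatter), a decrease beyond the scatter. Compound 3 is estimated at 6 nM, with a range from 2.5 nM to 15 nM.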

Compound 3, half-maximal inhibitory concentration: 31 nM
The estimate for compound 3 lay 5.2-fold (0.71 log units) below the measured number, outside the stated range (above it).
By their numbers in this assay, from the lowest: compound 1; then compounds 2 and 3 (each within the scatter of the next).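

In this assay, a carbon-only ring on the amide side chain does not by itself secure the low number of compound 1. Replacing the 3-methylphenyl with 3-(methoxymethyl)phenyl, which is methoxy in place of hydrogen on a saturated chain carbon bound to an aromatic carbon, gives a 6.3-fold higher number from compound 1 to compound 3 (0.80 log units; beyond the scatter). Exchanging pyridin-2-yl for 3-(methoxymethyl)phenyl gives a 1.2-fold higher number from compound 2 to compound 3 (0.09 log units; within the scatter), so this assay does not separate these two groups even though they differ in ring type and in heavy-atom count, and compound 1 remains the strongest inhibitor of the three, with compound 3 going against any general preference for a carbon-only ring over pyridin-2-yl.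

No measurement at hand explains why adding the methoxy to the methyl group changes the number so clearly. Still open, as far as these compounds go, is how a 3-ethylphenyl or a 3-(hydroxymethyl)phenyl at this place would compare with the 3-methylphenyl of compound 1, which would help show whether the oxygen or the length of the added chain tracks with the change.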